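This account rests on a few compounds, and the source may have more. Where it says the series, first, only, none or still open, it means among the compounds named here.

Series notes, adenosine receptor A3 displacement.

Three compounds of the shared core have been run in an assay on CHO cells for displacement of a labelled ligand from adenosine receptor A3 (Homo sapiens), read by scintillation counting, with a stated time of 120 min, tested at 10 uM; a lower number here means less inhibition, a higher number more inhibition at the concentration tested (going by the name of the read-out). Compound 1 `Nc1scc(CN2CCC(c3ccc(Cl)cc3)CC2)c1C(=O)c1ccc(Cl)cc1` gives 6% in this assay. Compound 2 `Nc1scc(CN2CCN(c3cccc(F)c3)CC2)c1C(=O)c1cccc(C(F)(F)F)c1` gives 0% in this assay. Compound 3 `Nc1scc(CN2CCN(C3CCCCCC3)CC2)c1C(=O)c1ccc(Cl)cc1` gives 0% in this assay; it is level with compound 2 at the digits shown, the two together the lowest of the three numbers, and compound 1 stands a number only slightly higher, within the scatter. None of the three shows any inhibition worth noting at the concentration tested.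

Compound 4 `Nc1scc(CN2CCN(c3cc(Cl)ccc3Cl)CC2)c1C(=O)c1ccc(Cl)cc1` is not yet measured. It differs from compound 3 in one place: 2,5-dichlorophenyl in place of cycloheptyl on an amine nitrogen in a ring. Compound 2 already carries an aryl group on that ring nitrogen and gives 0%, so an aryl in this place has not lifted the read-out so far. The step from compound 3 to compound 4 is expected to be none beyond the scatter in this assay, as a number 3 percentage points higher from compound 3 to compound 4 (within the scatter). Compound 4 is expected at 3%, within -8% to 15%.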

Compound 4, a percentage reported as inhibition, at one concentration (the size of the read-out at that concentration, not a potency): 1%
Compound 4: the middle estimate sits 2 percentage points above what was measured; the measured number falls inside the stated range.
By their numbers in this assay, from the lowest: compounds 2, 3, 4 and 1 (each within the scatter of the next).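

In this assay, 2,5-dichlorophenyl in place of cycloheptyl on the amine nitrogen in a ring gives a number 1 percentage points higher from compound 3 to compound 4 (within the scatter). Within the data shown here, this is the first one-place comparison at this position, and it shows that a seven-membered non-aromatic carbon ring and a dichlorinated aromatic ring cannot be told apart here at the concentration tested. No measurement at hand explains this flat result.

Because both compounds sit near the bottom of the read-out, the step cannot show whether this position is insensitive to change or whether the series simply lacks inhibition at this receptor. Still open, as far as these compounds go, is whether a group of another kind on that ring nitrogen, such as a carboxylic acid or a longer chain ending in an amine, would lift the number beyond the scatter.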